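A few compounds are considered here, and "the series" means these few. Any claim that something is new, unique, unknown or untested is made for them only; others in the source may bear on it.

Of the compounds shown here, three built on one shared core have been measured in an assay on isolated protein for inhibition of ATP-dependent RNA helicase DDX3X (Homo sapiens), read by FRET, with stated times of 30 s and 40 min; on this read-out higher numbers stand for weaker inhibition and lower numbers for stronger inhibition. Compound 1 `CC(C)CC(=O)OCCc1cn(-c2ccc(NC(=O)Nc3ccccc3C(F)(F)F)cc2)nn1` gives 400 nM. Compound 2 `CCCCc1cn(-c2ccc(NC(=O)Nc3cc(O)ccc3C)cc2)nn1` gives 490 nM, and compound 3 `Cc1ccccc1NC(=O)Nc1ccc(-n2cc(CCCN3CCN(C)CC3)nn2)cc1` gives 40100 nM. Compound 1 has the lowest number of the three, yet the number for compound 2 lies within the usual scatter of repeated measurements, so nothing separates these two; only compound 3 stands clearly apart, far beyond the scatter.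

Compound 4 `O=C(Nc1ccc(-n2cc(CCO)nn2)cc1)Nc1ccccc1C(F)(F)F` has not yet been measured. It differs from compound 1 in one place: hydrogen in place of isobutylcarbonyl on an oxygen on a saturated carbon. Seen one bond further out, the 2-((isobutylcarbonyl)oxy)ethyl of compound 1 becomes 2-hydroxyethyl in compound 4. Among the measured compounds shown here, no measured pair shows this change directly, so its effect has to be estimated from what the three numbers suggest. Compound 2, carrying a plain butyl chain, gives 490 nM, close to compound 1, while compound 3 with its long chain ending in a methylpiperazine gives a far higher number. A modest rise in this assay is expected, a 2.5-fold higher number from compound 1 to compound 4 (0.40 log units; beyond the scatter). Compound 4 is therefore estimated at about 1000 nM, with a likely range from 300 nM to 4000 nM.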

Compound 4, half-maximal inhibitory concentration: 11200 nM
Beside the measured number, compound 4's estimate is 11-fold (1.05 log units) below it, and the stated range ends below it.
By their numbers in this assay, from the lowest: compounds 1 and 2 (each within the scatter of the next); then compound 4; then compound 3.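

Cutting the isobutylcarbonyl from the oxygen, so that the 2-((isobutylcarbonyl)oxy)ethyl becomes a 2-hydroxyethyl, gives a 28-fold higher number from compound 1 to compound 4 (1.45 log units; beyond the scatter) in this assay and counts as a large step. Among the compounds shown here, this is the first direct look at this position, and it shows that what sits on this oxygen matters a great deal on this read-out: with all else held the same, the bare hydrogen gives far weaker inhibition than the isobutylcarbonyl. Nothing measured here bears on why the step is so large.

The compounds shown leave open whether a smaller acetyl or a longer acyl chain on the same oxygen would hold the lower number or lose it. They also leave open how a methyl ether, which caps the oxygen without a carbonyl, or an amide in place of the ester would compare.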